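A few compounds are considered here, and "the series" means these few. Any claim that something is new, unique, unknown or untested is made for them only; others in the source may bear on it.

Compound 1, `CCC(C)n1ncn(-c2ccc(N3CCN(c4ccc(OC[C@@H]5CO[C@@](Cc6ccccc6)(c6ccc(Cl)cc6Cl)O5)cc4)CC3)cc2)c1=O`, is the reference point here. Within the data shown here, in a functional assay on HUVEC cells (Homo sapiens), read by scintillation counting and thymidine incorporation, with a stated time of 24 h (on this read-out lower numbers stand for stronger inhibition and higher numbers for weaker inhibition), compound 1 gives 513 nM, the second highest of the three numbers measured so far. Compound 2, `CCC(C)n1ncn(-c2ccc(N3CCN(c4ccc(OC[C@@H]5CO[C@@](Cn6cnc(C)n6)(c6ccc(Cl)cc6Cl)O5)cc4)CC3)cc2)c1=O`, gives 272 nM, and compound 3, `CCC(C)n1ncn(-c2ccc(N3CCN(c4ccc(OC[C@@H]5CO[C@@](Cn6c(C)cnc6C)(c6ccc(Cl)cc6Cl)O5)cc4)CC3)cc2)c1=O`, gives 765 nM. Among the measured compounds shown here, only one of the measured steps, a 2.8-fold higher number from compound 2 to compound 3 (0.45 log units; beyond the scatter), reaches beyond the scatter.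

Compound 4, `CCC(C)n1ncn(-c2ccc(N3CCN(c4ccc(OC[C@@H]5CO[C@@](Cn6cc(C(F)(F)F)nc6C)(c6ccc(Cl)cc6Cl)O5)cc4)CC3)cc2)c1=O`, differs from compound 1 in one place: 2-methyl-4-(trifluoromethyl)-1H-imidazol-1-yl in place of phenyl on a saturated chain carbon bound to a saturated ring carbon. For the measured compounds named here, two measured steps bear on this change, since each of them also replaces the same phenyl with a small five-membered aromatic ring at the same place. One is a 1.9-fold lower number from compound 1 to compound 2 (0.28 log units; within the scatter), the other is a 1.5-fold higher number from compound 1 to compound 3 (0.17 log units; within the scatter). Both stay within the scatter, and they point in opposite directions, so this kind of exchange has so far moved the number in neither direction by a reliable amount. Going by the values given here, the group entering in compound 4 carries a trifluoromethyl that neither compound 2 nor compound 3 has, and nothing measured so far tells how that affects the number.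

Compound 4 is therefore expected to give about 600 nM, within a range from 250 nM to 1500 nM. This estimate means a step of a 1.2-fold higher number from compound 1 to compound 4 (0.07 log units; within the scatter), which is expected to stay within the scatter.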

Compound 4, half-maximal inhibitory concentration: 441 nM
Compound 4: the middle estimate sits 1.4-fold (0.13 log units) above what was measured; the range from low to high includes it.
By their numbers in this assay, from the lowest: compounds 2, 4, 1 and 3 (each within the scatter of the next, the first and the last beyond it).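

Replacing phenyl with a group of 10 heavy atoms, including 3 fluorine, on a saturated chain carbon bound to a saturated ring carbon still gives no reliable shift in this assay (a 1.2-fold lower number from compound 1 to compound 4 (0.07 log units; within the scatter)). The earlier compounds had not shown that a trifluoromethyl-bearing ring could stand at this place with a number that stays within the scatter of the phenyl compound. Compound 4 also lies within the scatter of both other ring-bearing compounds (a 1.7-fold lower number from compound 3 to compound 4 (0.24 log units; within the scatter); a 1.6-fold higher number from compound 2 to compound 4 (0.21 log units; within the scatter)), so it sits in the gap that separates compound 2 from compound 3, and nothing shown here offers an explanation for any of these numbers.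

As far as these compounds go, the effect of the trifluoromethyl alone stays open, since a comparison with the plain 2-methyl-1H-imidazol-1-yl group at this place would be needed to isolate it. It is also open whether a non-aromatic group here, such as a morpholine ring, a dimethylamino group or a carboxylic acid, would move the number beyond the scatter, as all the groups shown at this place are aromatic rings.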